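A few compounds are considered here, and "the series" means these few. Any claim that something is new, unique, unknown or untested is made for them only; others in the source may bear on it.

Measured compounds:
- compound 2, `CC(C)(C)OC(=O)N1CCC(CCCNc2ccc3c(c2)CNC3=O)CC1`: 102%
- compound 3, `COc1cnc(N2CCC(CCCNc3ccc4c(c3)OCC4=O)CC2)nc1`: 106%
- compound 1, `CC(C)(C)OC(=O)N1CCC(CCCNc2ccc3c(c2)OCCS3(=O)=O)CC1`: "not determined" (no result reported)

In a functional assay on CHO-K1 cells for agonist activity at Glucose-dependent insulinotropic receptor (Mus musculus), read by HTRF and cAMP accumulation, with a stated time of 30 min (a higher number here means a larger maximal response, a lower number a smaller maximal response), compound 2 gives 102% and compound 3 gives 106%. Compound 3 carries the higher of the two numbers, yet the gap to compound 2 lies within the scatter of this assay, so the two cannot be ordered. Compound 1 was not measured here, leaving only these two numbers as the basis for what follows.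

Compound 4, `CC(C)c1nnc(N2CCC(CCCNc3ccc4c(c3)OCC4=O)CC2)o1`, is the next step. Its structure differs from compound 3 in one place: 5-isopropyl-1,3,4-oxadiazol-2-yl in place of 5-methoxypyrimidin-2-yl on an amine nitrogen in a ring. The rest of the molecule, including the shared core and the chain leading to the ring amine, is kept.

Both measured compounds reach a full response in this assay, and the change is confined to the group on the ring amine, so no step beyond the scatter is expected in this assay; the step of a number 3 percentage points lower from compound 3 to compound 4 (within the scatter) is expected to be flat. Compound 4 is therefore estimated to give 103%, with a likely range from 92% to 114%.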

Compound 4, largest response reached (Emax), in percent of the reference or control that the assay uses: 88%
For compound 4 the middle estimate is 15 percentage points above the measured one; measured number below the stated range.
By their numbers in this assay, from the lowest: compound 4; then compounds 2 and 3 (each within the scatter of the next).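

In this assay the swap on the ring amine gives a number 18 percentage points lower from compound 3 to compound 4 (beyond the scatter) and so shows that the maximal response depends on which group sits on this amine nitrogen. The two groups have the same heavy-atom count and the same counts of hydrogen-bond donors and acceptors, so these counts alone do not account for the step. No measurement shown here gives a reason for it.

From the compounds shown here alone, the pair changes two things at once: the six-membered aromatic ring becomes a five-membered one, and methoxy gives way to isopropyl, so it remains open which of the two carries the step. A 5-isopropylpyrimidin-2-yl group on the same amine nitrogen, which pairs the six-membered ring with isopropyl, would help to separate these two changes.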